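Compound 2 to compound 4: swapping the nitrogen substituent

A few compounds are considered here, and "the series" means these few. Any claim that something is new, unique, unknown or untested is made for them only; others in the source may bear on it.

Of the compounds shown here, three have numbers so far: compound 1 (`O=S(=O)(Nc1ccc(-c2nc3cc(NS(=O)(=O)c4ccccc4)ccc3o2)cc1)c1ccccc1`), compound 2 (`COc1ccc(S(=O)(=O)Nc2ccc3oc(-c4ccc(NC(=O)c5cccc(C)c5[N+](=O)[O-])cc4)nc3c2)cc1`) and compound 3 (`O=S(=O)(Nc1ccc(-c2nc3cc(NS(=O)(=O)c4ccc(Br)cc4)ccc3o2)cc1)c1ccc(Br)cc1`). In a functional assay on HT-29 cells (Homo sapiens) for cytotoxicity, read by resazurin assay, with a stated time of 48 h (on this read-out higher numbers stand for an effect only at larger amounts of compound and lower numbers for an effect already at smaller amounts), compound 2 gives 2300 nM, the lowest of the three and beyond the scatter from the other two. Compound 4 (`COc1ccc(S(=O)(=O)Nc2ccc3oc(-c4ccc(NS(=O)(=O)c5cc(F)ccc5OC)cc4)nc3c2)cc1`) differs from compound 2 by a group of 12 heavy atoms (7 carbon, 3 oxygen, 1 fluorine, 1 sulfur; one six-membered aromatic ring of carbon only) in place of a group of 12 heavy atoms (8 carbon, 1 nitrogen, 3 oxygen; one six-membered aromatic ring of carbon only), on a nitrogen on an aromatic ring. Going by the values given here, no step between measured compounds isolates this change. The entering group holds sulfur, and sulfur-bearing groups also sit on that nitrogen in compound 1 at 16000 nM and compound 3 at 17000 nM. A higher number in this assay is therefore expected, probably short of those two values. The expected move is a 3.5-fold higher number from compound 2 to compound 4 (0.54 log units; beyond the scatter). For compound 4 the estimated value is 8000 nM, with an expected range of 2500 nM to 22000 nM.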

Compound 4, half-maximal effective concentration: 15000 nM
Compound 4: middle estimate off by 1.9-fold (0.27 log units), on the low side, within the range that was stated.
By their numbers in this assay, from the lowest: compound 2; then compounds 4, 1 and 3 (each within the scatter of the next).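

In this assay, replacing the (3-methyl-2-nitrophenyl)carbonyl group on this nitrogen with the sulfur-bearing group gives a 6.5-fold higher number from compound 2 to compound 4 (0.81 log units; beyond the scatter) and so shows that the position responds to the change even with the same heavy-atom, donor and acceptor counts. No measurement bears on the reason for this step.

Still open, going by these compounds, is whether the step follows from the carbonyl-to-sulfur link or from the ring substituents, as both change together. Also open, on these data alone, is how a free amine or an acetyl group on this nitrogen would compare.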